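The compounds below may be only part of what the source reports. "The series", "measured", "known", "first", "only" and "open" are said of these compounds alone.

Going by the values given here, compound 1 `CCc1ccccc1-c1nc(N)nc(N)n1` in a physicochemical assay for lipophilicity (a higher number here means a more lipophilic compound, a lower number a more polar compound), gives 1.65, the lowest of the three numbers measured so far. Compound 3 `Nc1nc(N)nc(-c2cccc(F)c2)n1` in this assay gives 1.73, a number within the scatter of compound 1, so no order can be read between those two. Compound 2 `CCN(CC)c1c(C)n(-c2ccccc2)c(=O)n(C)c1=O` in this assay gives 2.19, a number beyond the scatter and higher than compound 1. Compound 4 `Nc1nc(N)nc(-c2ccccc2[N+](=O)[O-])n1` is not yet measured; relative to compound 1 it carries nitro in place of ethyl on an aromatic carbon. Among the compounds with values here, no measured pair shows this change, so its size cannot be taken from the data. Compound 4 is expected to fall lower than compound 1 in this assay, with an expected step of a number 0.65 log units lower from compound 1 to compound 4 (beyond the scatter), beyond the scatter. Compound 4 is estimated at 1, with a range from 0.4 to 1.6.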

Compound 4, partition coefficient: 0.49
Beside the measured number, compound 4's estimate is 0.51 log units above it, within the range that was stated.
By their numbers in this assay, from the lowest: compound 4; then compounds 1 and 3 (each within the scatter of the next); then compound 2.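

In this assay, going by these compounds alone, nitro in place of ethyl on an aromatic carbon gives a number 1.16 log units lower from compound 1 to compound 4 (beyond the scatter) as the first one-place step, and a large one. This position, ortho to a group of 8 heavy atoms, therefore does not leave the read-out unchanged when its substituent is exchanged. No measurement shown gives a reason for the size of this step.

As far as these compounds go, how an amine, a methoxy group or a longer chain on the same carbon would compare stays open. From the compounds shown here alone, with a single pair carrying this change, whether its size holds on another core also stays open.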